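The source may hold more compounds than are shown below. What is called first, only, known or untested is meant among the compounds shown, and "the series" means these compounds.

In a functional assay on HeLa cells (Homo sapiens) for antiproliferative activity, read by MTT assay, with a stated time of 48 h (a lower number here means a stronger inhibitor, a higher number a weaker inhibitor), the series so far reads:

- compound 1 `Fc1ccc(-c2nn(-c3ccccc3)cc2-c2nc3cc(F)ccc3[nH]2)cc1` gives 1570 nM
- compound 2 `Fc1ccc(-c2nn(-c3ccccc3)cc2-c2nc3cc(Br)ccc3[nH]2)cc1` gives 4940 nM
- compound 3 `COc1ccc2[nH]c(-c3cn(-c4ccccc4)nc3-c3ccc(F)cc3)nc2c1` gives 7510 nM

Compound 3 is level with compound 2, the gap lying within the scatter (a 1.5-fold higher number from compound 2 to compound 3 (0.18 log units; within the scatter)), and stands apart from compound 1 by more than the scatter (a 4.8-fold higher number from compound 1 to compound 3 (0.68 log units; beyond the scatter)).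

The next compound is compound 4 `COc1ccc(-c2nn(-c3ccccc3)cc2-c2nc3cc(OC)ccc3[nH]2)cc1`. Its difference from compound 3 is methoxy in place of fluoro on an aromatic carbon on an aromatic carbon of a six-membered aromatic ring of carbon only, para to a large group, which reads as 4-fluorophenyl to 4-methoxyphenyl.

The same exchange of methoxy in place of fluoro has been measured once, in a modest step towards a higher number (a 4.8-fold higher number from compound 1 to compound 3 (0.68 log units; beyond the scatter)). That step removed a different fluoro, since compound 3 still carries the 4-fluorophenyl group. Bromo in place of fluoro also gave a modest step in that direction (a 3.1-fold higher number from compound 1 to compound 2 (0.50 log units; beyond the scatter)). Going by the values given here, no measured step touches the 4-fluorophenyl group itself, so the transfer is uncertain and the range stays wide.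

A modest rise is expected, somewhat smaller than the measured exchange, as an estimated 2.1-fold higher number from compound 3 to compound 4 (0.33 log units; beyond the scatter) in this assay overall. Compound 4 is therefore estimated at 16000 nM with an expected range of 6500 nM to 40000 nM in this read-out.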

Compound 4, half-maximal inhibitory concentration: 1140 nM
Compound 4: middle estimate off by 14-fold (1.15 log units), on the high side, and the stated range ends above it.
By their numbers in this assay, from the lowest: compounds 4 and 1 (each within the scatter of the next); then compounds 2 and 3 (each within the scatter of the next).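

In this assay, going by these compounds alone, the change from 4-fluorophenyl to 4-methoxyphenyl gives the first measured step at this place, on an aromatic carbon of a six-membered aromatic ring of carbon only, para to a large group (a 6.6-fold lower number from compound 3 to compound 4 (0.82 log units; beyond the scatter)), and it shows that a change here moves the number by more than the scatter, towards a stronger inhibitor. The same exchange of methoxy in place of fluoro, made at the other fluoro of the series, went the opposite way (a 4.8-fold higher number from compound 1 to compound 3 (0.68 log units; beyond the scatter)), so across these two steps the direction depends on where the exchange is made, and a reading from one place does not carry over to the other. Nothing at hand explains this difference in direction.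

Still open, as far as these compounds go, is whether the 4-methoxyphenyl group gives a step of the same direction and size when the other substituent on the core is fluoro or bromo rather than methoxy. Also open, from the compounds shown here alone, is how an unsubstituted phenyl, an amine, a carboxylic acid or a longer alkoxy chain would read at the place of the methoxy.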